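Swapping fluoro for bromo on the phenyl-bearing core

This account rests on a few compounds, and the source may have more. Where it says the series, first, only, none or still open, it means among the compounds named here.

Measured so far in an assay on isolated protein for inhibition of Indoleamine 2,3-dioxygenase 1 (Homo sapiens), read by spectrophotometry; on this read-out higher numbers stand for weaker inhibition and lower numbers for stronger inhibition:
compound 1 `O/N=C(/Nc1cccc(Br)c1)c1ccc2occc2c1` gives 440 nM
compound 2 `O/N=C(/Nc1cccc(F)c1)c1ccc2oc(-c3ccccc3)cc2c1` gives 11000 nM

Of the two numbers, compound 2 stands highest, meaning the weaker inhibition; compound 1 sits well below it, a gap beyond the usual scatter. Compound 3 `O/N=C(/Nc1cccc(Br)c1)c1ccc2oc(-c3ccccc3)cc2c1` keeps the core of compound 2 and differs only by bromo in place of fluoro on an aromatic carbon. Among the compounds with values here, no measured pair shows this swap on its own, so its size is uncertain; the expectation is a modest move toward stronger inhibition, estimated as a 2.2-fold lower number from compound 2 to compound 3 (0.34 log units; beyond the scatter). Compound 3 is therefore expected to give about 5000 nM, within 1500 nM to 15000 nM.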

Compound 3, half-maximal inhibitory concentration: 900 nM
For compound 3 the middle estimate is 5.6-fold (0.74 log units) above the measured one, and the stated range ends above it.
By their numbers in this assay, from the lowest: compound 1; then compound 3; then compound 2.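

In this assay bromo in place of fluoro on an aromatic carbon gives a 12-fold lower number from compound 2 to compound 3 (1.09 log units; beyond the scatter), so this single atom matters far more than the modest first guess allowed. With bromo held fixed, phenyl in place of hydrogen on an aromatic carbon gives only a 2.0-fold higher number from compound 1 to compound 3 (0.31 log units; beyond the scatter). Nothing available explains why the bromo step is so large. From the compounds shown here alone, whether chloro or methyl at this place would fall nearer to bromo or to fluoro stays open, as does whether the step keeps its size on the core without phenyl.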